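Aryl swaps on the shared core: toward compound 3

The source may hold more compounds than are shown below. What is called first, only, known or untested is meant among the compounds shown, and "the series" means these compounds.

Compound 1 `O=c1oc2ccccc2c2nc3c(ccc4cc[nH]c43)c(-c3cccnc3Cl)c12` carries a 2-chloropyridin-3-yl group on the shared core. In a functional assay on B16-F10 cells (Mus musculus) for cytotoxicity (on this read-out lower numbers stand for stronger inhibition and higher numbers for weaker inhibition), compound 1 gives 70700 nM. Compound 2 `O=c1oc2ccccc2c2nc3c(ccc4cc[nH]c43)c(-c3cccc4ccccc34)c12` differs only in that aryl group, and in this assay compound 2 gives 70700 nM. The one measured step, no change at the digits printed from compound 1 to compound 2 (within the scatter), exchanges one aryl group for another on an aromatic carbon and leaves the read-out unchanged, so compound 1 stands level with compound 2 at the digits shown, and neither can be called weaker or stronger than the other.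

Compound 3 `O=c1oc2ccccc2c2nc3c(ccc4cc[nH]c43)c(-c3ccc(O)cc3)c12` is not yet measured. Its change from compound 1 is 4-hydroxyphenyl in place of 2-chloropyridin-3-yl on an aromatic carbon. Among the measured compounds shown here, the only step that bears on it is no change at the digits printed from compound 1 to compound 2 (within the scatter), an aryl exchange at this position with no change beyond the scatter. For the measured compounds named here, no measured pair varies a hydrogen-bond donor on this group, so nothing bears on that part of the change. The expected step from compound 1 is therefore no change at the digits printed from compound 1 to compound 3 (within the scatter), none beyond the scatter. Compound 3 is estimated at 70700 nM in this assay, with a range of 30000 nM to 150000 nM.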

Compound 3, half-maximal inhibitory concentration: 70700 nM
Beside the measured number, compound 3's estimate shows no gap at the digits printed; low and high end bracket the measured number.
By their numbers in this assay, from the lowest: compounds 1, 2 and 3 (each within the scatter of the next).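

In this assay, 4-hydroxyphenyl brings a hydrogen-bond donor to this aromatic carbon, and the chlorine and ring nitrogen of 2-chloropyridin-3-yl leave, yet the read-out shows no change at the digits printed from compound 1 to compound 3 (within the scatter) and so gives no sign that this exchange matters here. Against naphthalen-1-yl, the same group gives no change at the digits printed from compound 2 to compound 3 (within the scatter) in the same assay, which extends the flat result to a third aryl group and to a pair differing in more than the ring hetero atom, so the three aryl groups on the shared core are not separated by this read-out. No measurement shown accounts for this flat result.

The compounds shown leave open whether anything other than an aryl group changes the read-out at this position, for example an aminomethyl group, a carboxylic acid or a longer alkyl chain. They also leave open whether the hydroxyl group of 4-hydroxyphenyl would count for anything at another place on that ring, or whether a methoxy group in its stead would read the same.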